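Benzofuran for thiophene on two pyrrolopyrimidine nucleoside cores

The compounds below may be only part of what the source reports. "The series", "measured", "known", "first", "only" and "open" are said of these compounds alone.

Measured so far in a functional assay on CCRF-CEM cells (Homo sapiens), read by MTT assay, with a stated time of 72 h; on this read-out higher numbers stand for weaker inhibition and lower numbers for stronger inhibition:
- compound 1, `Cc1nc(N)c2c(-c3cccs3)cn([C@@H]3O[C@H](CO)[C@@H](O)[C@H]3O)c2n1`, reaches only the limit > 20000 nM
- compound 2, `Cc1nc(N)c2c(-c3cc4ccccc4o3)cn([C@@H]3O[C@H](CO)[C@@H](O)[C@H]3O)c2n1`, reaches only the limit > 20000 nM
- compound 3, `CN(C)c1ncnc2c1c(-c1cccs1)cn2[C@@H]1O[C@H](CO)[C@@H](O)[C@H]1O`, reaches only the limit > 20000 nM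

From compound 1 to compound 2 the change is 1-benzofuran-2-yl in place of thiophen-2-yl on an aromatic carbon; its effect is a step that the two limits leave unreadable from compound 1 to compound 2, since (the limit of > 20000 nM in this assay, at which 3 of the 3 values shown sit). Compound 3 carries a different core, and the difference between the two cores is not broken down here. Compound 4, `CN(C)c1ncnc2c1c(-c1cc3ccccc3o1)cn2[C@@H]1O[C@H](CO)[C@@H](O)[C@H]1O`, arises from compound 3 by the same change, (1-benzofuran-2-yl in place of thiophen-2-yl on an aromatic carbon). Because (the limit of > 20000 nM in this assay, at which 3 of the 3 values shown sit), the step that the limit leaves unreadable from compound 3 to compound 4 is expected to stay unreadable in this assay , and compound 4 is estimated at 30000 nM, within 10000 nM to 100000 nM, most likely again as a limit.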

Compound 4, half-maximal inhibitory concentration: > 20000 nM
Compound 4 gave a limit, no number; the forecaster's own chance of this, stated with the estimate: 85%; the middle value lies beyond the limit too.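

No step can be read from compound 3 to compound 4, since both values are limits: the limit of > 20000 nM in this assay, at which 4 of the 4 values shown sit.

The compounds shown leave open whether 1-benzofuran-2-yl and thiophen-2-yl differ at all on either core, and how strongly any of the four compounds inhibits.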